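The source may hold more compounds than are shown below. What is called first, only, known or untested is meant among the compounds shown, and "the series" means these compounds.

Working notes on the series. The shared core is carried unchanged through compound 1 (`C[C@H](O)[C@@H](CCc1cccc(-c2cnccn2)c1)n1cnc2c(N)ncnc21`) and compound 2 (`C[C@H](O)[C@@H](CCc1cccc(C(=O)O)c1)n1cnc2c(N)ncnc21`); they differ only in the substituent on the aromatic carbon. In an assay on isolated protein for inhibition of adenosine deaminase (Bos taurus), with a stated time of 5 min (on this read-out lower numbers stand for stronger inhibition and higher numbers for weaker inhibition), compound 1 gives 1.9 nM, and compound 2 gives 53 nM. For the measured compounds named here, the one measured step, a 28-fold higher number from compound 1 to compound 2 (1.45 log units; beyond the scatter), is large, and compound 2 therefore stands at the highest of the two numbers so far.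

The next compound, `C[C@H](O)[C@@H](CCc1cccc(C(N)=O)c1)n1cnc2c(N)ncnc21` (compound 3), differs from compound 2 by amino in place of hydroxy on a carbonyl carbon. Going by the values given here, no measured step bears directly on this change: the only step available, a 28-fold higher number from compound 1 to compound 2 (1.45 log units; beyond the scatter), concerns the exchange of pyrazin-2-yl for carboxy, not carboxy for carbamoyl. The expectation for compound 3 is therefore loosely held, and is set as a modest lowering of the number, a 3.5-fold lower number from compound 2 to compound 3 (0.55 log units; beyond the scatter). On that basis compound 3 is estimated at 15 nM, with a range of 3 nM to 80 nM.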

Compound 3, inhibition constant: 2.9 nM
Compound 3: middle estimate off by 5.2-fold (0.71 log units), on the high side, and the stated range ends above it.
By their numbers in this assay, from the lowest: compounds 1 and 3 (each within the scatter of the next); then compound 2.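

In this assay, a change of one heavy atom on the carbonyl carbon, amino in place of hydroxy, gives a large step, an 18-fold lower number from compound 2 to compound 3 (1.26 log units; beyond the scatter), so the higher number of compound 2 does not extend to every carbonyl-bearing group at this aromatic carbon. The other new step, a 1.5-fold higher number from compound 1 to compound 3 (0.18 log units; within the scatter), lies within the scatter, so carbamoyl and pyrazin-2-yl cannot be told apart here, and a ring on this carbon is not needed for a number in this range. Nothing measured accounts for the difference between carboxy and carbamoyl.

The compounds shown leave open whether a methyl ester, a nitrile or a dimethylamide at this aromatic carbon would read like compound 2 or like compound 3. They also leave open where a sulfonamide or a simple amine would fall.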